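This account rests on a few compounds, and the source may have more. Where it says the series, first, only, none or still open, it means among the compounds named here.

Series notes. Compound 1 `Brc1ccc2[nH]c(-c3cncn3Cc3ccccc3)cc2c1` gives 13600 nM in an assay on isolated protein for inhibition of Indoleamine 2,3-dioxygenase 1 (Homo sapiens), with a stated time of 1 h; a higher number here means a weaker inhibitor, a lower number a stronger inhibitor. Among the measured compounds shown here, compound 2 `N#Cc1ccc(Cn2cncc2-c2cc3cc(Br)ccc3[nH]2)cc1` gives 3810 nM in this assay, the lowest of the two numbers so far; the single measured step, a 3.6-fold lower number from compound 1 to compound 2 (0.55 log units; beyond the scatter), separates it from compound 1. Compound 3 `Brc1ccc2[nH]c(-c3cncn3CC3CCCCN3)cc2c1` differs from compound 2 by piperidin-2-yl in place of 4-cyanophenyl on a saturated chain carbon bound to an aromatic nitrogen. For the measured compounds named here, no measured step covers this exchange; the only one available, a 3.6-fold lower number from compound 1 to compound 2 (0.55 log units; beyond the scatter), concerns the nitrile that now leaves along with its whole ring, so the gain seen there is not expected to carry over. For compound 3 an upward step, a 3.9-fold higher number from compound 2 to compound 3 (0.60 log units; beyond the scatter), is expected, giving an estimated 15000 nM with a range from 5000 nM to 50000 nM.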

Compound 3, half-maximal inhibitory concentration: > 100000 nM
Compound 3: no number, only a limit; the forecaster's own chance of this, stated with the estimate: 15%; middle value at least 6.6-fold (0.82 log units) away from the limit.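

The value of compound 3 is a limit, not a number: the limit of > 100000 nM in this assay, at which 1 of the 3 values shown sits. Piperidin-2-yl in place of 4-cyanophenyl gives an at least 26-fold higher number from compound 2 to compound 3 (1.41 log units; beyond the scatter), and in place of phenyl it gives an at least 7.3-fold higher number from compound 1 to compound 3 (0.86 log units; beyond the scatter). The earlier compounds shown here showed only a change on the aromatic ring at this position, whereas these steps show that exchanging the whole ring costs far more, and that the loss does not rest on the nitrile alone.

The compounds shown leave open whether the loss follows from the ring being non-aromatic or from its ring nitrogen. A cyclohexyl group on the same carbon would separate the two.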